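Adding a Second Chloro Group on a Rearranged Core

The source may hold more compounds than are shown below. What is called first, only, known or untested is meant among the compounds shown, and "the series" means these compounds.

Measured so far:
compound 1 `ClCc1ccccc1Cn1cnc2c(Cl)nc(Cl)nc21` 3540 nM
compound 2 `ClCc1ccccc1Cn1cnc2c(Cl)ncnc21` 15900 nM
compound 3 `ClCc1ccccc1Cn1cnc2ncnc(Cl)c21` 26900 nM

These three compounds were tested in a functional assay on SK-OV-3 cells (Homo sapiens) for cytotoxicity, read by sulforhodamine B assay, with a stated time of 48 h; on this read-out higher numbers stand for weaker inhibition of growth and lower numbers for stronger inhibition of growth. Compound 1 and compound 2 share one core, and compound 1 carries one chloro group more: chloro in place of hydrogen on an aromatic carbon. That change gave a 4.5-fold lower number from compound 2 to compound 1 (0.65 log units; beyond the scatter). Compound 3 has the same atoms as compound 2, joined differently; the difference between the two cores is not broken down here. Its number is the highest of the three, though its gap to compound 2 lies within the scatter.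

Compound 4 `ClCc1ccccc1Cn1cnc2nc(Cl)nc(Cl)c21` has not yet been measured in this assay. It differs from compound 3 in the same way that compound 1 differs from compound 2: chloro in place of hydrogen on an aromatic carbon. The place of the new chloro group is described in the same words for both pairs, so the change is the same. The expectation therefore rests on compound 1 and compound 2, whose change gave a 4.5-fold lower number from compound 2 to compound 1 (0.65 log units; beyond the scatter), and compound 4 is expected to show a step of a 3.8-fold lower number from compound 3 to compound 4 (0.58 log units; beyond the scatter). On this basis compound 4 is estimated at 7000 nM, with a likely range from 2500 nM to 20000 nM.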

Compound 4, concentration for total growth inhibition: 20900 nM
Compound 4: the middle estimate sits 3.0-fold (0.48 log units) below what was measured; the whole stated range lies below it.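

In this assay the step on the core of compound 3 is a 1.3-fold lower number from compound 3 to compound 4 (0.11 log units; within the scatter), so here the new chloro group leaves the number within the usual scatter of repeated measurements. Set beside the earlier step, the same change did not carry over in size from one core to the other: the same change on two cores in this assay, a 4.5-fold lower number (0.65 log units; beyond the scatter) from compound 2 to compound 1 and a 1.3-fold lower number (0.11 log units; within the scatter) from compound 3 to compound 4, 3.5-fold (0.54 log units) apart, beyond the scatter of two such steps. This shows that a step seen on one of these two cores cannot simply be applied to the other, but two pairs do not show why the cores differ or how the change would behave on any further core.

For the compounds shown here, the only group that enters in these pairs is chloro, so it remains open whether an amine or a methoxy group on the same aromatic carbon would give steps that also differ between the two cores. It also remains open whether the gap between the two steps would hold in cell lines other than the one shown here.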